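A few compounds are considered here, and "the series" means these few. Any claim that something is new, unique, unknown or untested is made for them only; others in the source may bear on it.

Values in a functional assay on K562 cells (Homo sapiens) for cytotoxicity, read by trypan blue exclusion, with a stated time of 96 h; on this read-out higher numbers stand for weaker inhibition and lower numbers for stronger inhibition
- compound 1 `COc1ccc(NS(=O)(=O)/C=C/c2c(OC)cc(OC)cc2OC)cc1`: 75 nM
- compound 2 `COc1cc(OC)c(/C=C/S(=O)(=O)Nc2ccc(OC)c(F)c2)c(OC)c1`: 75 nM
- compound 3 `COc1cc(OC)c(/C=C/S(=O)(=O)Nc2ccc(OC)c(O)c2)c(OC)c1`: 15 nM

Compound 3 has the lowest number of the three, and its gaps to both others lie beyond the scatter. Compound 4 `COc1cc(OC)c(/C=C/S(=O)(=O)Nc2ccc(OC)c(OP(=O)(O)O)c2)c(OC)c1` is reached through (a group of 4 heavy atoms (3 oxygen, 1 phosphorus; no ring) in place of a hydrogen atom, on an oxygen on an aromatic ring), which removes the hydroxy hydrogen of compound 3. Within the data shown here, two steps bear on this: a 5.0-fold lower number from compound 1 to compound 3 (0.70 log units; beyond the scatter) and a 5.0-fold lower number from compound 2 to compound 3 (0.70 log units; beyond the scatter), both gaining that hydroxy. The step of no change at the digits printed from compound 1 to compound 2 (within the scatter) adds little here. Among the measured compounds shown here, no measured step covers substitution on that oxygen, so the inference is loose. Part of the modest hydroxy gain is expected to be lost, giving a higher number in this assay. The expected change is a 2.7-fold higher number from compound 3 to compound 4 (0.43 log units; beyond the scatter). The estimate for compound 4 is 40 nM, with an expected range of 12 nM to 150 nM.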

Compound 4, half-maximal inhibitory concentration: 7.5 nM
The estimate for compound 4 lay 5.3-fold (0.73 log units) above the measured number; measured number outside the range, below it.
By their numbers in this assay, from the lowest: compounds 4 and 3 (each within the scatter of the next); then compounds 1 and 2 (each within the scatter of the next).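

In this assay, the hydroxy hydrogen of compound 3 is not required at this oxygen on an aromatic ring: the group of 4 heavy atoms (3 oxygen, 1 phosphorus) gives a 2.0-fold lower number from compound 3 to compound 4 (0.30 log units; within the scatter), so this substitution does not lose the hydroxy gain. The advantage remains in a 10-fold lower number from compound 2 to compound 4 (1.00 log units; beyond the scatter) and in a 10-fold lower number from compound 1 to compound 4 (1.00 log units; beyond the scatter). Nothing available explains this tolerance.

Open, on these data alone, is whether other groups on this oxygen, such as methyl or a longer chain ending in a carboxylic acid, behave alike. As far as these compounds go, an amine in place of the hydroxy is also open.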